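Varying the group on the sulfonyl sulfur

The source may report more compounds than this note shows. Statements on the series, on what has been measured and on what is new or still open speak of the compounds shown alone.

Of the compounds shown here, three sharing one core have been measured in a functional assay, read by fluorescence and spectrophotometry, with a stated time of 1 h; on this read-out higher numbers stand for an effect only at larger amounts of compound and lower numbers for an effect already at smaller amounts: compound 1 `O=S(=O)(/C=C/c1ccc(O)c(O)c1)CC1CC1`, compound 2 `CCCCCS(=O)(=O)/C=C/c1ccc(O)c(O)c1` and compound 3 `O=S(=O)(/C=C/c1ccc(O)c(O)c1)CC1CCCC1`. In this assay compound 1 gives 10500 nM, compound 2 gives 8100 nM and compound 3 gives 9400 nM. The number for compound 2 stands lowest of the three shown, but the steps of a 1.3-fold lower number from compound 1 to compound 2 (0.11 log units; within the scatter) and a 1.2-fold higher number from compound 2 to compound 3 (0.06 log units; within the scatter) are both within the scatter, as is a 1.1-fold lower number from compound 1 to compound 3 (0.05 log units; within the scatter); none of the three compounds can be set apart from the others on these numbers.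

Compound 4 `O=S(=O)(/C=C/c1ccc(O)c(O)c1)CCCC1CCCCC1` is not yet measured. Relative to compound 2 the change is cyclohexyl in place of ethyl on a saturated chain carbon, three bonds along the chain from a sulfonyl sulfur. All three measured steps alter the group on the saturated chain carbon bound to the sulfonyl sulfur, and none of them moved this assay beyond the scatter; the change to compound 4 lies further out along the same chain. A step beyond the scatter in either direction is therefore not expected. The expected step is a 1.0-fold lower number from compound 2 to compound 4 (0.01 log units; within the scatter). Compound 4 is estimated at 8000 nM, with a range from 4000 nM to 16000 nM.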

Compound 4, half-maximal effective concentration: 7900 nM
Beside the measured number, compound 4's estimate is 1.0-fold (0.01 log units) above it; the measured number falls inside the stated range.
By their numbers in this assay, from the lowest: compounds 4, 2, 3 and 1 (each within the scatter of the next).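

In this assay, the change from ethyl to cyclohexyl on a saturated chain carbon, three bonds along the chain from a sulfonyl sulfur, gives a 1.0-fold lower number from compound 2 to compound 4 (0.01 log units; within the scatter). The earlier steps shown here altered only the group on the saturated chain carbon bound to the sulfonyl sulfur, whereas this one shows that a chain ending in a six-membered non-aromatic ring of carbon only, with 6 heavy atoms entering for 2, can be placed at this new position without a step beyond the scatter. No measurement shown accounts for this absence of a measurable step.

Going by these compounds, whether an amine or a carboxylic acid at this position would move the number beyond the scatter remains open. Every compound shown keeps the shared core, so the effect of any change there also remains open.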